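A few compounds are considered here, and "the series" means these few. Any claim that something is new, unique, unknown or untested is made for them only; others in the source may bear on it.

Measured in a functional assay on PC-3 cells (Homo sapiens) for antiproliferative activity, read by WST assay, with a stated time of 3 days; a higher number here means a weaker inhibitor, a lower number a stronger inhibitor:
- Compound 1 `CCOc1c(-c2cc(OC)c(OC)c(OC)c2)oc2ccccc2c1=O`: 900 nM
- Compound 2 `CCCCCCOc1c(-c2cc(OC)c(OC)c(OC)c2)oc2ccccc2c1=O`: 29200 nM
- Compound 3 `CCCN(CCC)CCCOc1c(-c2cc(OC)c(OC)c(OC)c2)oc2ccccc2c1=O`: 16800 nM

Compound 3 stands at the weak end of these numbers, level with compound 2 within the scatter and far above compound 1. Compound 4 `CCCN(CCC)CCCCCOc1c(-c2cc(OC)c(OC)c(OC)c2)oc2ccccc2c1=O` differs from it by 2-(dipropylamino)ethyl in place of dipropylamino on a saturated chain carbon, three bonds along the chain from an oxygen on an aromatic ring: 3-(dipropylamino)propyl becomes 5-(dipropylamino)pentyl.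

Two large steps came with a longer chain: a 32-fold higher number from compound 1 to compound 2 (1.51 log units; beyond the scatter), and a 19-fold higher number from compound 1 to compound 3 (1.27 log units; beyond the scatter). Once the chain was long, changing its end made little difference: a 1.7-fold lower number from compound 2 to compound 3 (0.24 log units; within the scatter). For the measured compounds named here, no measured pair lengthens a chain that already ends in dipropylamino, so this remains uncertain. The expected step in this assay is a 1.1-fold higher number from compound 3 to compound 4 (0.03 log units; within the scatter), and none beyond the scatter is expected. For compound 4 the estimate is 18000 nM, with an expected range of 7000 nM to 45000 nM.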

Compound 4, half-maximal inhibitory concentration: 2600 nM
Beside the measured number, compound 4's estimate is 6.9-fold (0.84 log units) above it; measured number below the stated range.
By their numbers in this assay, from the lowest: compound 1; then compound 4; then compounds 3 and 2 (each within the scatter of the next).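

In this assay, chain length still matters when the chain ends in dipropylamino: 5-(dipropylamino)pentyl in place of 3-(dipropylamino)propyl gives a 6.5-fold lower number from compound 3 to compound 4 (0.81 log units; beyond the scatter). At this longer length the chain end also counts, with an 11-fold lower number from compound 2 to compound 4 (1.05 log units; beyond the scatter), whereas the earlier shorter amine chain stayed within the scatter of the hexyl chain. The short ethyl chain still holds the lower number, with a 2.9-fold higher number from compound 1 to compound 4 (0.46 log units; beyond the scatter). Nothing available explains these shifts. Going by these compounds, whether 4-(dipropylamino)butyl, a longer chain, or a piperidine at the chain end would lower the number further remains open.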